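Shortening the hexyloxy chain to butyloxy on the core

A few compounds are considered here, and "the series" means these few. Any claim that something is new, unique, unknown or untested is made for them only; others in the source may bear on it.

In an ADME assay on Akata cells (Homo sapiens) for cytotoxicity, with a stated time of 7 days (a higher number here means that more compound is tolerated, a lower number that less compound is tolerated), compound 2 `CCCCCCOc1nc(N)nc2c1ncn2/C=C1/CC1(CO)CO` gives > 20000 nM, which is a limit of the assay rather than a number. Compound 1 `CN(C)c1nc(N)nc2c1ncn2/C=C1/CC1(CO)CO` likewise gives only a limit in this assay, namely > 24000 nM. For the measured compounds named here, the single measured step, a step that the two limits leave unreadable from compound 1 to compound 2, therefore has no readable size. Compound 3 `CCCCOc1nc(N)nc2c1ncn2/C=C1/CC1(CO)CO` differs from compound 2 by hydrogen in place of ethyl on a saturated chain carbon, four bonds along the chain from an oxygen on an aromatic ring. Going by the values given here, no measured step bears on this change, and both values so far sit at limits, so the step that the limit leaves unreadable from compound 2 to compound 3 is expected to stay within the scatter. Compound 3 is accordingly expected to give 30000 nM in this assay, between 15000 nM and 80000 nM, most likely again as a limit.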

Compound 3, half-maximal cytotoxic concentration: > 20000 nM
Compound 3 was reported as a limit (the forecaster's own chance of this, stated with the estimate: 85%); the middle value lies beyond the limit too.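

For the compounds shown here, no step among compound 1, compound 2 and compound 3 can be read in this assay: each gives only a limit. The compounds shown leave open at what concentration any of them becomes cytotoxic, and whether the alkoxy chain length matters.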